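This account rests on a few compounds, and the source may have more. Where it says the series, first, only, none or still open, it means among the compounds named here.

Measured so far in a functional assay on isolated protein for inhibition of Glucose-dependent insulinotropic receptor (Rattus norvegicus), read by HTRF and cAMP accumulation; on this read-out lower numbers stand for smaller maximal responses and higher numbers for larger maximal responses:

- compound 1 `Cc1nc(S(C)(=O)=O)ccc1Oc1ncnc(OC2CCN(C(=O)OC3CCC3)CC2)c1F`: 81%
- compound 2 `Cc1nc(S(C)(=O)=O)ccc1Oc1ncnc(OC2CCN(C(=O)OC(C)(C)C#N)CC2)c1F`: 97%

Compound 2 stands highest of the two numbers measured; the nearest is compound 1, and the step of a number 16 percentage points higher from compound 1 to compound 2 (beyond the scatter) lies beyond the scatter. Among the measured compounds shown here, that step exchanges cyclobutyl for 1-cyano-1-methylethyl on an oxygen next to a carbonyl group and is the only step measured so far.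

Compound 3 `Cc1nc(S(C)(=O)=O)ccc1Oc1ncnc(OC2CCN(C(=O)OC(C)(C)CF)CC2)c1F` has not yet been measured. Relative to compound 2 the change is fluoromethyl in place of cyano on a saturated chain carbon bound to an oxygen next to a carbonyl group and two saturated chain carbons. For the measured compounds named here, no measured step touches this change: the step from compound 1 to compound 2 alters the whole group on the oxygen next to the carbonyl group, whereas here only the cyano at the end of that group is replaced by fluoromethyl. Going by the values given here, the one step available therefore gives no direction for this exchange, and the expectation is a step of no more than modest size, if any beyond the scatter.

For compound 3 the estimate in this assay is 90%, with a range from 75% to 105%, which means an expected step of a number 7 percentage points lower from compound 2 to compound 3 (within the scatter).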

Compound 3, largest response reached (reported as efficacy), in percent of the reference or control that the assay uses: 95%
Beside the measured number, compound 3's estimate is 5 percentage points below it, within the range that was stated.
By their numbers in this assay, from the lowest: compound 1; then compounds 3 and 2 (each within the scatter of the next).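

In this assay, fluoromethyl in place of cyano on a saturated chain carbon bound to an oxygen next to a carbonyl group and two saturated chain carbons gives a number 2 percentage points lower from compound 2 to compound 3 (within the scatter), so at this position the two groups cannot be told apart by this read-out, and the nitrile is not needed to hold the response at this level. 1-(Fluoromethyl)-1-methylethyl in place of cyclobutyl gives a number 14 percentage points higher from compound 1 to compound 3 (beyond the scatter), which, like a number 16 percentage points higher from compound 1 to compound 2 (beyond the scatter), lies beyond the scatter, so in these three compounds the difference from the cyclobutyl compound appears with either of the two open-chain groups and does not rest on the nitrile alone. Nothing at hand gives a reason for these numbers.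

The compounds shown leave open whether the end of this group tolerates exchange more widely, for instance a plain methyl, which would make the tert-butyl group, or a hydroxymethyl or aminomethyl in the same place. They also leave open whether the gain over cyclobutyl would hold for a longer chain on the same oxygen or for an open-chain group lacking the two methyl groups.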